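Swapping the chloropyridinyl ring of compound 1 for ethoxyphenyl

A few compounds are considered here, and "the series" means these few. Any claim that something is new, unique, unknown or untested is made for them only; others in the source may bear on it.

Compound 1 `COc1ccccc1-n1nc(C2CC(C)(C)OC(C)(C)C2)cc1-c1ccnc(Cl)c1` was tested in an assay on HEK293 cells for inhibition of Voltage-dependent N-type calcium channel subunit alpha-1B (Homo sapiens), read by patch clamp, using a membrane potential dye (a lower number here means a stronger inhibitor, a higher number a weaker inhibitor), and gave 250 nM. Compound 2 `COc1ccccc1-n1nc(C2CC(C)(C)OC(C)(C)C2)cc1-c1ccc(C#N)cc1` was tested in the same way, and in this assay compound 2 gave 85 nM. Within the data shown here, of the two numbers so far, compound 1 stands highest, and its nearest neighbour is compound 2, which differs from it by the single step of a 2.9-fold lower number from compound 1 to compound 2 (0.47 log units; beyond the scatter).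

Compound 3 `CCOc1ccc(-c2cc(C3CC(C)(C)OC(C)(C)C3)nn2-c2ccccc2OC)cc1` has not yet been measured in this assay. It differs from compound 1 in one place: 4-ethoxyphenyl in place of 2-chloropyridin-4-yl on an aromatic carbon.

Among the measured compounds shown here, the only measured step that bears on this change is the one in which a 4-cyanophenyl replaced the 2-chloropyridin-4-yl; that step, a 2.9-fold lower number from compound 1 to compound 2 (0.47 log units; beyond the scatter), was beyond the scatter but modest. The change to compound 3 likewise exchanges the 2-chloropyridin-4-yl for a six-membered aromatic ring of carbon only, yet the group that enters is 4-ethoxyphenyl rather than 4-cyanophenyl, so the measured step is only a partial guide. A lowering of roughly the same modest size is expected, though with wide uncertainty: the estimated step is a 2.1-fold lower number from compound 1 to compound 3 (0.32 log units; beyond the scatter). For compound 3 the expected value in this assay is therefore 120 nM, within a range from 40 nM to 400 nM.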

Compound 3, half-maximal inhibitory concentration: 29 nM
Compound 3: the middle estimate sits 4.1-fold (0.62 log units) above what was measured, and the stated range ends above it.
By their numbers in this assay, from the lowest: compound 3; then compound 2; then compound 1.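

At this aromatic carbon next to the ring nitrogen, the 4-ethoxyphenyl group takes the number in this assay further than the 4-cyanophenyl group did, and the full exchange of the 2-chloropyridin-4-yl ring amounts to an 8.6-fold lower number from compound 1 to compound 3 (0.94 log units; beyond the scatter) in place of the smaller step seen earlier. With the carbon-only ring held constant, ethoxy in place of cyano still gives a 2.9-fold lower number from compound 2 to compound 3 (0.47 log units; beyond the scatter) on its own, so the group carried on that ring counts here, and the exchange of the ring itself does not account for the whole change. Nothing at hand explains why ethoxy goes with the lower number.

From the compounds shown here alone, it remains open whether the ethoxy chain length or its oxygen is what counts, a question that a methoxy, a propoxy or an ethyl group on the same ring would address. Going by these compounds, it also remains open how an amine or a carboxylic acid on that ring would read, and whether ethoxy would give a similar step on the 2-chloropyridin-4-yl ring.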